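Replacing the End of a Butyl Chain with Phenyl

The compounds below may be only part of what the source reports. "The series", "measured", "known", "first", "only" and "open" are said of these compounds alone.

Among the compounds with values here, in a functional assay (Nicotiana tabacum) (on this read-out lower numbers stand for stronger inhibition and higher numbers for weaker inhibition), compound 1 (`CCCCNc1nc(SC)nc2ncccc12`) gives 270 nM, the lowest of the three numbers so far. Compound 3 (`CCC(C)Nc1nc(SC)nc2ncccc12`) gives 860 nM, and compound 2 (`CSc1nc(NC2CC2)c2cccnc2n1`) gives 4900 nM. Compound 4 (`CSc1nc(NCc2ccccc2)c2cccnc2n1`) differs from compound 1 by phenyl in place of propyl on a saturated chain carbon bound to a nitrogen on an aromatic ring. Two measured changes to the group on that nitrogen both raised the number: sec-butyl gave a 3.2-fold higher number from compound 1 to compound 3 (0.50 log units; beyond the scatter), and cyclopropyl gave an 18-fold higher number from compound 1 to compound 2 (1.26 log units; beyond the scatter). Neither introduces phenyl, so they are only a rough guide. The expected change is a modest rise, a 2.6-fold higher number from compound 1 to compound 4 (0.41 log units; beyond the scatter). For compound 4 the estimated value is 700 nM, with an expected range of 150 nM to 3000 nM.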

Compound 4, half-maximal inhibitory concentration: 25200 nM
For compound 4 the middle estimate is 36-fold (1.56 log units) below the measured one; the whole stated range lies below it.
By their numbers in this assay, from the lowest: compound 1; then compound 3; then compound 2; then compound 4.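

In this assay, phenyl in place of propyl gives a 93-fold higher number from compound 1 to compound 4 (1.97 log units; beyond the scatter), a larger rise than either sec-butyl or cyclopropyl produced. Within the data shown here, this shows that the group on this nitrogen can cost far more activity than the earlier compounds suggested, and that a six-membered aromatic ring on the saturated chain carbon does not stand in for propyl here.

From the compounds shown here alone, whether a longer chain such as hexyl, or a chain ending in an amine, would match or improve on compound 1 remains open. Nothing shown explains the size of this rise.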